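The source may hold more compounds than are shown below. What is called first, only, known or untested is meant among the compounds shown, and "the series" means these compounds.

Measured compounds:
Compound 1 `Oc1cccc(-c2cc(-c3ccccc3F)cc(-c3ccccc3O)n2)c1` — 31100 nM
Compound 2 `Oc1ccc(-c2cc(-c3ccccc3F)cc(-c3ccccc3O)n2)cc1` — > 50000 nM
Compound 3 `Oc1ccc(-c2cc(-c3cccc(OC(F)(F)F)c3)cc(-c3cccc(O)c3)n2)cc1` — 14100 nM

In a functional assay on HeLa cells (Homo sapiens) for inhibition (a higher number here means a weaker inhibitor, a lower number a stronger inhibitor), compound 1 gives 31100 nM. For compound 2 the value is a limit of the assay, not a number: the limit of > 50000 nM in this assay, at which 1 of the 3 values shown sits. The change between them is 4-hydroxyphenyl in place of 3-hydroxyphenyl on an aromatic carbon, and it made an at least 1.6-fold higher number from compound 1 to compound 2 (0.20 log units; that floor lies within the scatter). Compound 3 gives 14100 nM in this assay; how its core differs from that of compound 1 is not broken down here. Compound 4 `Oc1ccc(-c2cc(-c3cccc(OC(F)(F)F)c3)cc(-c3ccc(O)cc3)n2)cc1` is not yet measured, and it differs from compound 3 by 4-hydroxyphenyl in place of 3-hydroxyphenyl on an aromatic carbon. This is the same kind of change as from compound 1 to compound 2, though the surroundings differ: there the place was meta to a 2-fluorophenyl group and meta to a 2-hydroxyphenyl group, here it is meta to a 4-hydroxyphenyl group and meta to a large group. Since the earlier step gave only a floor, compound 4 is expected to be a weaker inhibitor, with a step of a 2.1-fold higher number from compound 3 to compound 4 (0.33 log units; beyond the scatter). The estimate for compound 4 in this assay is 30000 nM, between 12000 nM and 70000 nM.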

Compound 4, half-maximal inhibitory concentration: > 50000 nM
Compound 4: a limit, no number (the forecaster's own chance of this, stated with the estimate: 35%); middle value at least 1.6-fold (0.22 log units) away from the limit.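

In this assay, 4-hydroxyphenyl in place of 3-hydroxyphenyl gave an at least 3.5-fold higher number from compound 3 to compound 4 (0.54 log units; beyond the scatter), so on the core of compound 3 the change clearly weakens inhibition. Compound 4 reads > 50000 nM, which is a limit of the assay and not a number. The change therefore has no exact size on either core, and the two results show neither that the effect carries over unchanged nor that it depends on the core: the same change on two cores in this assay, an at least 1.6-fold higher number (0.20 log units; that floor lies within the scatter) from compound 1 to compound 2 and an at least 3.5-fold higher number (0.54 log units; beyond the scatter) from compound 3 to compound 4; the limit leaves it open whether they differ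

Still open, from the compounds shown here alone, is what other groups would do on that ring, such as an amine or a carboxylic acid in place of the hydroxy group. Compounds at the limit also cannot be ranked against each other: the limit of > 50000 nM in this assay, at which 2 of the 4 values shown sit.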